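The compounds below may be only part of what the source reports. "The series", "measured", "known", "first", "only" and "open" are said of these compounds alone.

Measured so far in a physicochemical assay for lipophilicity, at pH 7.4; on this read-out higher numbers stand for higher lipophilicity and lower numbers for lower lipophilicity:
compound 1, `Cc1cc(C(=O)O)nn1Cc1cc(Br)ccc1OCc1ccccc1`, gives 1.2
compound 2, `Cc1cc(C(=O)O)nn1C(C)c1cc(Cl)ccc1OCc1ccccc1`, gives 1
compound 3, `Cc1cc(C(=O)NC(C)C)nn1Cc1cc(Cl)ccc1OCc1ccccc1`, gives > 3.7

Compound 3 stands apart from the other two. Its result in this assay is not a number but a limit of the assay, at which one of the three results sits (the limit of > 3.7 in this assay, at which 1 of the 3 values shown sits). Compounds 1 and 2 carry a free carboxylic acid on the shared core, while compound 3 carries an amide in that place, and the readings of compounds 1 and 2 lie close together.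

Compound 4, `Cc1cc(C(=O)NCc2ccccc2)nn1Cc1cc(Cl)ccc1OCc1ccccc1`, has not yet been measured. It keeps the whole of compound 3 except for one change: benzyl in place of isopropyl on an amide-type nitrogen. The amide itself stays; only the group hanging from its nitrogen grows from a short branched chain to a seven-atom ring-bearing group.

Within the data shown here, since no pair of measured compounds differs in exactly one place, the size of the step has to be guessed rather than read off. Compound 3 already sits at a limit, so the expectation for compound 4 is that this assay again reports a limit or a number at the high end, with the step from compound 3 to compound 4 expected at a step that the limit leaves unreadable from compound 3 to compound 4. Compound 4 is thus expected to come out at about 4.8, within a range from 4 to 5.6.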

Compound 4, distribution coefficient: > 3.7
Compound 4 gave a limit, no number (the forecaster's own chance of this, stated with the estimate: 85%); the middle value does not contradict the limit.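

In this assay, compound 3 and compound 4 each give a limit and not a number, so no step between them can be read: the limit of > 3.7 in this assay, at which 2 of the 4 values shown sit.

The compounds shown leave open where compound 3 and compound 4 truly sit on this read-out, and so whether benzyl in place of isopropyl changes the reading at all.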